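A few compounds are considered here, and "the series" means these few. Any claim that something is new, unique, unknown or untested is made for them only; others in the source may bear on it.

Series notes. In a functional assay on A549 cells (Homo sapiens) for inhibition, read by XTT assay, with a stated time of 48 h (a higher number here means a weaker inhibitor, a lower number a stronger inhibitor), compound 3 `C=C(C(=O)c1ccc(OC)cc1)C(OC(=O)c1ccccc1)C(CC)CC` gives 35200 nM, the lowest of the two numbers in hand. Compound 2 `C=C(C(=O)c1ccc(OC)cc1)C(OC(=O)c1ccccc1)c1ccc(Cl)cc1Cl` gives 79200 nM, with a 2.3-fold lower number from compound 2 to compound 3 (0.35 log units; beyond the scatter). Compound 1 `C=C(C(=O)c1ccc(OC)cc1)C(OC(C)=O)C1CCCCC1` returns only a limit, > 100000 nM, as recorded in the limit of > 100000 nM in this assay, at which 1 of the 3 values shown sits. Compound 4 `C=C(C(=O)c1ccc(OC)cc1)C(OC(=O)c1ccccc1)C1CCCCC1` differs from compound 3 by cyclohexyl in place of pentan-3-yl on a saturated chain carbon bound to a double-bonded chain carbon and an oxygen next to a carbonyl group. Among the compounds with values here, the only measured step at that position is the modest one from compound 2 to compound 3. Within the data shown here, compound 1 carries the same cyclohexyl as compound 4 but differs from it in a second place as well, and its result is a limit; no measured step bears directly on the move to compound 4. Relative to compound 3, compound 4 is expected to show a step of a 1.3-fold higher number from compound 3 to compound 4 (0.11 log units; within the scatter) within the scatter, giving an estimated 45000 nM (range 20000 nM to 120000 nM) in this assay.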

Compound 4, half-maximal inhibitory concentration: 62100 nM
Beside the measured number, compound 4's estimate is 1.4-fold (0.14 log units) below it, within the range that was stated.
By their numbers in this assay, from the lowest: compounds 3, 4 and 2 (each within the scatter of the next, the first and the last beyond it). At a limit, above all of these: compound 1.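

In this assay, cyclohexyl at this position sits within the scatter of both neighbours, with a 1.8-fold higher number from compound 3 to compound 4 (0.25 log units; within the scatter) and a 1.3-fold lower number from compound 2 to compound 4 (0.11 log units; within the scatter). A ring of carbon only is therefore not separated from the open pentan-3-yl chain or from 2,4-dichlorophenyl, although those two groups do differ from each other. Compound 1 is a limit, so phenyl in place of methyl on a carbonyl carbon yields only a floor, an at least 1.6-fold lower number from compound 1 to compound 4 (0.20 log units; that floor lies within the scatter).

Open, on these data alone, is whether an amine or a carboxylic acid on this saturated chain carbon would give a step beyond the scatter.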